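This account rests on a few compounds, and the source may have more. Where it says the series, first, only, none or still open, it means among the compounds named here.

In a functional assay on MCF7 cells (Homo sapiens) for inhibition, read by fluorescence, with a stated time of 72 h (a higher number here means a weaker inhibitor, a lower number a stronger inhibitor), the measured compounds are:

- compound 1 `CC(C)Cn1cnc2c(NC(=N)N)nc(N)nc21` with 96600 nM
- compound 2 `CC[C@H](N)COc1nc(NC(=N)N)c2ncn(C(C)C)c2n1` with 16300 nM

Compound 2 at 16300 nM holds the lower of the two numbers, which makes it the stronger inhibitor of this pair, and its gap to compound 1 lies beyond the scatter. The next candidate is compound 3 `CC(C)n1cnc2c(NC(=N)N)nc(OC[C@@H]3CCCN3)nc21`, still unmeasured. It has pyrrolidin-2-yl in place of 1-aminopropyl on a saturated chain carbon bound to an oxygen on an aromatic ring. Cut one bond further out, this is 2-aminobutoxy changing to (pyrrolidin-2-yl)methoxy. Within the data shown here, no two measured compounds differ in one place only, so the data offer no direct precedent for this change. With so little to go on, no step beyond the scatter is expected in this assay, and any shift would more likely be slightly downward. The expected size is a 1.2-fold lower number from compound 2 to compound 3 (0.07 log units; within the scatter) as an estimate. Compound 3 is estimated at 14000 nM with an expected range from 5000 nM to 40000 nM in this assay.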

Compound 3, half-maximal inhibitory concentration: > 100000 nM
Compound 3 gave a limit, no number (the forecaster's own chance of this, stated with the estimate: 5%); middle value at least 7.1-fold (0.85 log units) from the limit.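

In this assay compound 3 gives > 100000 nM, which is a limit of the assay and not a number. Exchanging 1-aminopropyl for pyrrolidin-2-yl on a saturated chain carbon bound to an oxygen on an aromatic ring gives an at least 6.1-fold higher number from compound 2 to compound 3 (0.78 log units; beyond the scatter), so this position does respond to the change, and 2-aminobutoxy and (pyrrolidin-2-yl)methoxy are not interchangeable in this assay. This step fixes only the least possible size of the loss, and it rests on a limit: the limit of > 100000 nM in this assay, at which 1 of the 3 values shown sits.

As far as these compounds go, whether the loss follows from the five-membered ring itself remains open, since a piperidin-2-yl ring or an open chain such as 2-aminoethoxy could show whether other groups here fare any better. From the compounds shown here alone, how far compound 3 really lies beyond its limit also stays unknown.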